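Varying the aryl group on the carbonyl carbon: working notes

The source may hold more compounds than are shown below. What is called first, only, known or untested is meant among the compounds shown, and "the series" means these compounds.

Measured so far in a functional assay on A2780 cells (Homo sapiens) for cytotoxicity, read by MTT assay, with a stated time of 68 h; a lower number here means a stronger inhibitor, a higher number a weaker inhibitor:
compound 1 `O=C(/C=C/c1cccc(OCc2ccccc2)c1)c1ccccc1Br` gives 2500 nM
compound 2 `COc1ccc(C(=O)/C=C/c2cccc(OCc3ccccc3)c2)cc1` gives 38100 nM
compound 3 `O=C(/C=C/c1cccc(OCc2ccccc2)c1)c1ccc(Cl)cc1Cl` gives 21400 nM

Compound 3 stands second highest of the three numbers, nearest to compound 2 and furthest from compound 1. Compound 4 `O=C(/C=C/c1cccc(OCc2ccccc2)c1)c1ccc([N+](=O)[O-])cc1` differs from compound 3 by 4-nitrophenyl in place of 2,4-dichlorophenyl on a carbonyl carbon. Among the measured compounds shown here, two measured steps bear on this change: a 1.8-fold lower number from compound 2 to compound 3 (0.25 log units; within the scatter), a swap at the same carbonyl carbon that stays within the scatter, and an 8.6-fold higher number from compound 1 to compound 3 (0.93 log units; beyond the scatter), which lies beyond it; a 15-fold higher number from compound 1 to compound 2 (1.18 log units; beyond the scatter) runs the same way. For the measured compounds named here, no measured compound carries 4-nitrophenyl, so the swap rests on the 4-methoxyphenyl comparison alone. In this assay no step beyond the scatter is therefore expected for compound 4, a 1.2-fold higher number from compound 3 to compound 4 (0.07 log units; within the scatter). Compound 4 is estimated at 25000 nM, range 8000 nM to 70000 nM.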

Compound 4, half-maximal inhibitory concentration: 56400 nM
For compound 4 the middle estimate is 2.3-fold (0.35 log units) below the measured one; the measured number falls inside the stated range.
By their numbers in this assay, from the lowest: compound 1; then compounds 3, 2 and 4 (each within the scatter of the next, the first and the last beyond it).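

At the carbonyl carbon, this assay shows a 2.6-fold higher number from compound 3 to compound 4 (0.42 log units; beyond the scatter) and so separates 4-nitrophenyl from 2,4-dichlorophenyl, whereas a 1.5-fold higher number from compound 2 to compound 4 (0.17 log units; within the scatter) stays within the scatter. Among the compounds shown here, with a 23-fold higher number from compound 1 to compound 4 (1.35 log units; beyond the scatter) as the largest step, compound 1 is the strongest of the four, and 2-bromophenyl remains the only aryl group set apart from all the others. No available evidence explains these differences. From the compounds shown here alone, it remains open whether the low number of compound 1 depends on the bromine or would persist with 2-chlorophenyl or unsubstituted phenyl on the carbonyl carbon.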